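This account rests on a few compounds, and the source may have more. Where it says the series, first, only, none or still open, it means among the compounds named here.

Compound 2 `Cc1ccc(NC(=O)c2ccccc2OCCCCn2ccnc2)cc1Nc1nccc(-c2cccnc2)n1` in a functional assay on K-562R cells (Homo sapiens) for cytotoxicity, read by XTT assay, with a stated time of 24 h (a lower number here means a stronger inhibitor, a higher number a weaker inhibitor), gives 83400 nM, the highest number of the three measured, though both neighbours sit within the scatter of it: compound 3 `Cc1ccc(NC(=O)c2cc(I)ccc2OCCCCn2ccnc2)cc1Nc1nccc(-c2cccnc2)n1` gives 81700 nM and compound 1 `Cc1ccc(NC(=O)c2ccc(Br)cc2OCCCCn2ccnc2)cc1Nc1nccc(-c2cccnc2)n1` gives 44600 nM. Among the compounds with values here, the two steps so far are small. Removing bromo from an aromatic carbon gives a 1.9-fold higher number from compound 1 to compound 2 (0.27 log units; within the scatter); adding iodo on an aromatic carbon gives a 1.0-fold lower number from compound 2 to compound 3 (0.01 log units; within the scatter). Neither halogen change moved this assay beyond its scatter.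

Compound 4 `Cc1ccc(NC(=O)c2ccc(I)cc2OCCCCn2ccnc2)cc1Nc1nccc(-c2cccnc2)n1` differs from compound 2 by iodo in place of hydrogen on an aromatic carbon. Both measured steps bear on it: one shows what a halogen at the place where compound 4 carries iodo does, the other what iodo elsewhere on the same ring does, and each stays within the scatter. No step beyond the scatter is therefore expected, with at most a slight lowering of the number. The step expected is a 1.5-fold lower number from compound 2 to compound 4 (0.18 log units; within the scatter). For compound 4 the estimate in this assay is 55000 nM, within a range of 22000 nM to 140000 nM.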

Compound 4, half-maximal inhibitory concentration: 51800 nM
For compound 4 the middle estimate is 1.1-fold (0.03 log units) above the measured one; the range from low to high includes it.
By their numbers in this assay, from the lowest: compounds 1, 4, 3 and 2 (each within the scatter of the next).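

At the place para to a large group and meta to a 4-(1H-imidazol-1-yl)butoxy group, iodo now joins bromo as a tested halogen: in this assay, iodo in place of hydrogen gives a 1.6-fold lower number from compound 2 to compound 4 (0.21 log units; within the scatter). Exchanging one halogen for the other at this same place gives a 1.2-fold higher number from compound 1 to compound 4 (0.06 log units; within the scatter), so bromo and iodo cannot be told apart here. No measurement shown accounts for how close these numbers lie.

The compounds shown leave open whether an amine, a carboxylic acid or a methoxy group at this place would give a step beyond the scatter. Also open, on these data alone, is whether a shorter or longer chain in place of the 4-(1H-imidazol-1-yl)butoxy group would do so.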